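The source may hold more compounds than are shown below. What is called first, only, known or untested is meant among the compounds shown, and "the series" means these compounds.

Measured so far:

Compound 1 `CCCCNC(=O)NS(=O)(=O)c1ccc(-n2nc(-c3ccc(OC)cc3)ccc2=O)cc1` gives 43.7% in a functional assay on the whole organism (blood, strain Wistar albino) for inhibition, with Rattus norvegicus as the target, read by colorimetric assay, with stated times of 15 min and 90 min, at a dose of 20 mg/kg by the oral route; on this read-out higher numbers stand for more inhibition at the one dose given (going by the name of the read-out) and lower numbers for less inhibition.
Compound 2 `CCCNC(=O)NS(=O)(=O)c1ccc(-n2nc(-c3ccc(C)cc3)ccc2=O)cc1` gives 80.5% in this assay.

Of the two numbers, compound 2 stands highest, and its gap to compound 1 is beyond the usual scatter of this kind of measurement. Compound 1 and compound 2 differ from each other in more than one place, so their two values show only that one sits well above the other, not which part of the structure is responsible.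

Compound 3 `CCCCNC(=O)NS(=O)(=O)c1ccc(-n2nc(-c3ccc(C)cc3)ccc2=O)cc1` has not yet been measured. It differs from compound 2 in a single place: methyl in place of hydrogen on a saturated chain carbon, three bonds along the chain from an amide-type nitrogen. Cut one bond further out, the propyl chain of compound 2 becomes a butyl chain in compound 3, while everything else stays the same.

Within the data shown here, a one-carbon lengthening of a saturated chain of this kind usually moves this read-out only modestly, and nothing among the measured compounds points to a direction. The expected step is a number 8.5 percentage points lower from compound 2 to compound 3 (within the scatter), a change that may well sit within the scatter. Compound 3 is therefore expected to give about 72% in this assay, with a plausible range from 50% to 88%.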

Compound 3, a percentage reported as inhibition, in the whole organism at one dose (the size of the read-out at that dose, not a potency): 86.6%
Estimate against measurement, compound 3: 14.6 percentage points below; measured number inside the range.
By their numbers in this assay, from the lowest: compound 1; then compounds 2 and 3 (each within the scatter of the next).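

Lengthening the propyl chain to a butyl chain gives a number 6.1 percentage points higher from compound 2 to compound 3 (within the scatter) in this assay, so at this one dose the added methyl on the chain carbon makes no difference that can be told from the scatter. Among these compounds, compound 3 also provides the first comparison that isolates a change on the aromatic carbon: with the butyl chain held constant, methyl in place of methoxy gives a number 42.9 percentage points higher from compound 1 to compound 3 (beyond the scatter), a large step that links this position to a clear difference, which the two earlier compounds could not do because they differ in more than one place. Nothing available here offers a reason for either step.

The compounds shown leave open whether the read-out would hold with a longer chain such as pentyl or hexyl, or with a chain ending in an amine. They also leave open how other groups on the aromatic carbon, such as chlorine or a carboxylic acid, would compare with methyl and methoxy, and how any of these compounds would behave at other doses.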